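This account rests on a few compounds, and the source may have more. Where it says the series, first, only, none or still open, it means among the compounds named here.

Three compounds have been measured in a functional assay on MOLT-4 cells (Homo sapiens); on this read-out higher numbers stand for weaker inhibition and lower numbers for stronger inhibition:

Compound 1 `Cn1ncc2c1[C@@H](CO[Si](c1ccccc1)(c1ccccc1)C(C)(C)C)C[C@H]2Cn1cnc2c(O)ncnc21`: 3.2 ug/mL
Compound 2 `OC[C@H]1C[C@@H](Cn2cnc3c(Cl)ncnc32)c2ccccc21`: 24 ug/mL
Compound 3 `Cn1ncc2c1[C@H](Cn1cnc3c(Cl)nc(N)nc31)C[C@@H]2CO`: 3.2 ug/mL

Compound 2 stands highest of the three and so is the weakest inhibitor in this small set. Its value of 24 ug/mL lies beyond the scatter from both of the others, compound 1 at 3.2 ug/mL and compound 3 at 3.2 ug/mL.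

The next compound to be tested, compound 4 `OC[C@H]1C[C@@H](Cn2cnc3c(NC4CC4)ncnc32)c2ccccc21`, keeps the frame of compound 2 but carries cyclopropylamino in place of chloro on an aromatic carbon. This position sits on a six-membered aromatic ring with 2 nitrogen, part of a fused system of two rings.

Among the compounds with values here, compound 1 and compound 3 each differ from compound 2 in more than one place, so no measured pair isolates this swap. The data therefore give no direct guide to its size or direction. The expectation in this assay is cautious: a small move towards a higher number, with no real change beyond the scatter as the likeliest outcome. The expected step is a 1.5-fold higher number from compound 2 to compound 4 (0.16 log units; within the scatter). For compound 4 the estimated value is 35 ug/mL, with an expected range from 12 ug/mL to 100 ug/mL.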

Compound 4, half-maximal inhibitory concentration: 24 ug/mL
For compound 4 the middle estimate is 1.5-fold (0.16 log units) above the measured one, and the stated range covers the measured number.
By their numbers in this assay, from the lowest: compounds 1 and 3 (each within the scatter of the next); then compounds 2 and 4 (each within the scatter of the next).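

In this assay, within the data shown here, the only comparison in this set that isolates a single place, cyclopropylamino in place of chloro on an aromatic carbon, gives no change at the digits printed from compound 2 to compound 4 (within the scatter), so this position on the frame of compound 2 accepts the exchange without a read-out shift beyond the scatter. The change is not a small one on paper: a single chlorine leaves, and four heavy atoms enter, bringing a three-membered ring, a hydrogen-bond donor and a hydrogen-bond acceptor, yet the number stays where it was. No measurement at hand explains why the exchange leaves the read-out as it is.

Going by these compounds, what remains open is whether this flat result holds for other groups at the same carbon, such as a plain amine, dimethylamino, morpholine or a longer chain such as n-butylamino, any of which could separate from chloro where cyclopropylamino does not. On these data alone, it also remains open whether the same exchange would behave alike on the core of compound 3, which differs from compound 2 in more than one place.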